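The source may report more compounds than this note shows. Statements on the series, on what has been measured and on what is new or still open speak of the compounds shown alone.

Measured compounds in a functional assay on the whole organism (strain Wistar) for inhibition, with Rattus norvegicus as the target, read by paw edema, with a stated time of 3 h, at a dose of 100 umol/kg by the oral route; on this read-out higher numbers stand for more inhibition at the one dose given (going by the name of the read-out) and lower numbers for less inhibition:
compound 1, `CS(=O)(=O)c1ccc(Nc2c(-c3ccccn3)nc3ccccn23)cc1`: 18.5%
compound 2, `c1ccc(Nc2c(-c3ccccc3)nc3ccccn23)cc1`: 63.9%
compound 3, `c1ccc(Nc2c(-c3ccncc3)nc3ccccn23)cc1`: 49.9%

Compound 3 stands second highest of the three numbers, below compound 2 and well above compound 1. Among the compounds with values here, the one measured step that touches this part of the molecule is a number 14 percentage points lower from compound 2 to compound 3 (beyond the scatter), where a pyridine ring took the place of a phenyl ring. Compound 4, `c1ccc(Nc2c(-c3ccccn3)nc3ccccn23)cc1`, keeps the pyridine but moves its nitrogen: pyridin-2-yl in place of pyridin-4-yl on an aromatic carbon. Within the data shown here, no measured pair shows this swap on its own; compound 1 carries the same pyridin-2-yl group but also a different anilino group, so its value alone cannot fix the direction. The expected step is therefore small, a number 7.9 percentage points lower from compound 3 to compound 4 (within the scatter), with a wide range. Compound 4 is estimated at 42%, between 20% and 65%.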

Compound 4, a percentage reported as inhibition, in the whole organism at one dose (the size of the read-out at that dose, not a potency): 33.4%
For compound 4 the middle estimate is 8.6 percentage points above the measured one, and the stated range covers the measured number.
By their numbers in this assay, from the lowest: compound 1; then compound 4; then compound 3; then compound 2.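

In this assay the place of the ring nitrogen matters on its own: the two compounds have the same atoms, yet the change to pyridin-2-yl gives a number 16.5 percentage points lower from compound 3 to compound 4 (beyond the scatter) here. Measured against the phenyl ring, the same group gives a number 30.5 percentage points lower from compound 2 to compound 4 (beyond the scatter) and is the lowest of the three groups tried at this position. With pyridin-2-yl held fixed, hydrogen in place of methylsulfonyl gives a number 14.9 percentage points higher from compound 1 to compound 4 (beyond the scatter) as well, so the anilino group also counts.

On these data alone, how pyridin-3-yl would fare at this position stays open. Nothing available here explains why the nitrogen's place matters.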